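Phenyl in Place of Thiophen-2-yl: Expected Growth Inhibition

The source may report more compounds than this note shows. Statements on the series, on what has been measured and on what is new or still open speak of the compounds shown alone.

Compound 1, `Cn1cccc1-c1cc(-c2cccs2)nc(N)c1C#N`: > 100000 nM
Compound 2, `COc1ccc(-c2cc(-c3cccn3C)c(C#N)c(N)n2)cc1OC`: 83200 nM
Compound 3, `Cn1cccc1-c1cc(-c2cccs2)[nH]c(=O)c1C#N`: > 100000 nM

Of the compounds shown here, three have been tested in a functional assay on SF-539 cells (Homo sapiens) for inhibition, read by sulforhodamine B assay, with a stated time of 48 h; a lower number here means a stronger inhibitor of growth, a higher number a weaker inhibitor of growth. For compound 1 the result is a limit of the assay, > 100000 nM, and not a number. For compound 3 the result is likewise a limit, > 100000 nM. For the measured compounds named here, compound 2 gives 83200 nM, the only number among the three. Compound 1 therefore stands at the weak end of what is shown, sharing (the limit of > 100000 nM in this assay, at which 2 of the 3 values shown sit).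

Compound 4, `Cn1cccc1-c1cc(-c2ccccc2)nc(N)c1C#N`, has not yet been measured in this assay. It differs from compound 1 in one place: phenyl in place of thiophen-2-yl on an aromatic carbon. Going by the values given here, no step between measured compounds is available to guide the expectation, and compound 2 shows that a six-membered carbon ring can still give only weak inhibition of growth. Compound 4 is expected to remain a weak inhibitor in this assay, with an estimated a number no higher from compound 1 to compound 4 (the limit leaves the size open) amounting to no step beyond the scatter. The estimate for compound 4 is 100000 nM, with a range from 40000 nM to 300000 nM, and a fair chance that the assay again reports only a limit.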

Compound 4, concentration for 50% growth inhibition: 33900 nM
Beside the measured number, compound 4's estimate is 2.9-fold (0.47 log units) above it; the measured number lies below the stated range.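

In this assay, for the compounds shown here, phenyl in place of thiophen-2-yl on the aromatic carbon next to the ring nitrogen gives an at least 2.9-fold lower number from compound 1 to compound 4 (0.46 log units; beyond the scatter), the first readable step in this set, and it shows that the result at this position depends on which ring sits there. With the amino group, the cyano group and the 1-methyl-1H-pyrrol-2-yl group unchanged, compound 4 gives a measured number, 33900 nM. Compound 1 gives a limit and not a number, so the full size of the step stays open: the limit of > 100000 nM in this assay, at which 2 of the 4 values shown sit.

The compounds shown leave open how a furan-2-yl or pyridin-3-yl group would behave at this position. Also open, on these data alone, is whether phenyl would give a measured number in compound 3, which has a carbonyl where compound 4 has its amino group.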